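Removing the nitro group from compound 1

A few compounds are considered here, and "the series" means these few. Any claim that something is new, unique, unknown or untested is made for them only; others in the source may bear on it.

compound 1 `Cc1ccc2[nH]c(=O)c(-c3nc4cc([N+](=O)[O-])ccc4[nH]3)cc2c1` — > 100000 nM, a limit of the assay
compound 2 `O=c1[nH]c2ccccc2cc1-c1nc2cc([N+](=O)[O-])ccc2[nH]1` — > 100000 nM, a limit of the assay

In a functional assay on NCI-H460 cells (Homo sapiens) for cytotoxicity, read by MTT assay, with a stated time of 48 h (on this read-out lower numbers stand for stronger inhibition and higher numbers for weaker inhibition), compound 1 gives only a limit, > 100000 nM. In this assay compound 2 likewise gives only a limit, > 100000 nM. For the measured compounds named here, the single step between them, a step that the two limits leave unreadable from compound 1 to compound 2, therefore cannot be read in either direction, and the sole evidence on the measured steps is the limit of > 100000 nM in this assay, at which 2 of the 2 values shown sit. Compound 1 thus stands at the limit of this assay, with no number of its own and no neighbour that carries one.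

Compound 3 `Cc1ccc2[nH]c(=O)c(-c3nc4ccccc4[nH]3)cc2c1` differs from compound 1 in one place: hydrogen in place of nitro on an aromatic carbon. Going by the values given here, no measured step bears on this change; the one step known, from compound 1 to compound 2, concerns a methyl and its size is not readable. With compound 1 sitting at the limit, the step from compound 1 to compound 3 is expected to be a number no higher from compound 1 to compound 3 (the limit leaves the size open), with its direction open. Compound 3 is therefore estimated at about 100000 nM in this assay, within 30000 nM to 300000 nM, and most probably reported again only as a limit.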

Compound 3, half-maximal inhibitory concentration: > 100000 nM
Compound 3 ended at the assay's limit; the forecaster's own chance of this, stated with the estimate: 75%; the middle value lies on the limit itself.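

In this assay compound 3 gives > 100000 nM, which is a limit of the assay and not a number. Compound 1 also gives only a limit, so no step between compound 1 and compound 3 can be read: the limit of > 100000 nM in this assay, at which 3 of the 3 values shown sit.

The compounds shown leave open whether the nitro or the methyl group makes any difference in this assay.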